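Truncating the amide side of a spiro-piperidine cholesterol-transport series

A few compounds are considered here, and "the series" means these few. Any claim that something is new, unique, unknown or untested is made for them only; others in the source may bear on it.

Of the compounds shown here, three of one core have been measured. In an assay on HEK293 cells for displacement of a labelled ligand from NPC1-like intracellular cholesterol transporter 1 (Homo sapiens) (on this read-out lower numbers stand for stronger inhibition and higher numbers for weaker inhibition), compound 1 `CCC1CCCN(C(=O)CN2CN(c3ccccc3)C3(CCN(C(=O)c4ccc(C(C)(C)C)cc4)CC3)C2=O)C1` gives 3900 nM, the lowest number of the three; compound 2 `CC(C)(C)OC(=O)NCCNC(=O)CN1CN(c2ccccc2)C2(CCN(C(=O)c3ccc(C4CCCCC4)cc3)CC2)C1=O` gives 5500 nM, and compound 3 `O=C(CN1CN(c2ccccc2)C2(CCN(C(=O)c3ccc(C4CCCCC4)cc3)CC2)C1=O)NCO` gives 8300 nM. Compound 1 and compound 2 lie within the scatter of each other, while the gap from compound 1 to compound 3 lies beyond it. Going by the values given here, the one measured step, a 1.5-fold higher number from compound 2 to compound 3 (0.18 log units; within the scatter), concerns the chain on the amide-type nitrogen and stays within the scatter.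

Compound 4 `CC(C)(C)c1ccc(C(=O)N2CCC3(CC2)C(=O)N(CC(=O)NCN)CN3c2ccccc2)cc1` is unmeasured. It differs from compound 1 in that ((aminomethyl)amino in place of 3-ethylpiperidin-1-yl on a carbonyl carbon). This step too alters the group carried by that carbonyl, and compounds 2 and 3, which carry chains on an amide-type nitrogen rather than a ring, both give higher numbers than compound 1. A modest rise in this assay is therefore expected, with a 1.9-fold higher number from compound 1 to compound 4 (0.28 log units; within the scatter) likely to reach beyond the scatter but not far. Compound 4 is estimated at 7500 nM, within a range from 3000 nM to 19000 nM.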

Compound 4, half-maximal inhibitory concentration: 26500 nM
The estimate for compound 4 lay 3.5-fold (0.55 log units) below the measured number; the measured number lies above the stated range.
By their numbers in this assay, from the lowest: compounds 1, 2 and 3 (each within the scatter of the next, the first and the last beyond it); then compound 4.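

In this assay, this carbonyl carbon proves sensitive to the group it carries: putting (aminomethyl)amino in place of 3-ethylpiperidin-1-yl gives a 6.8-fold higher number from compound 1 to compound 4 (0.83 log units; beyond the scatter). The earlier step, a 1.5-fold higher number from compound 2 to compound 3 (0.18 log units; within the scatter), stayed within the scatter, so this is the first single-place change shown that moves the number beyond it, and the move is towards weaker inhibition. Nothing available bears on why the number rises.

This one step removes the ring and the ethyl group and brings in hydrogen-bond donors all at once, so the compounds shown cannot say which of these changes matters. A plain piperidin-1-yl or a diethylamino group on the same carbonyl, on the core of compound 1, would separate the ring and the ethyl group from the donors.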